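Allyloxy in place of isobutoxy on the shared core

A few compounds are considered here, and "the series" means these few. Any claim that something is new, unique, unknown or untested is made for them only; others in the source may bear on it.

Three compounds share one core and differ only in the group on the oxygen on the aromatic ring. Compound 1 `CC(C)COc1ccc2c(Cl)ccnc2c1` gives 3030 nM in a functional assay on BGC-823 cells (Homo sapiens) for cytotoxicity, read by MTT assay, with a stated time of 48 h (a higher number here means a weaker inhibitor, a lower number a stronger inhibitor), and stands highest of the three numbers, though within the scatter of both others. Compound 2 `Clc1ccnc2cc(OCCc3ccccc3)ccc12` gives 2010 nM and compound 3 `Clc1ccnc2cc(OCCCc3ccccc3)ccc12` gives 2370 nM; the step of a 1.2-fold higher number from compound 2 to compound 3 (0.07 log units; within the scatter) is within the scatter. Compound 4 `C=CCOc1ccc2c(Cl)ccnc2c1` carries the change (vinyl in place of isopropyl on a saturated chain carbon bound to an oxygen on an aromatic ring). No measured step touches this change, and the one step shown was small, so a step beyond the scatter is not expected. The expected step is a 1.0-fold lower number from compound 1 to compound 4 (0.00 log units; within the scatter). Compound 4 is therefore estimated at 3000 nM, within the range 1200 nM to 7500 nM.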

Compound 4, half-maximal inhibitory concentration: 2930 nM
Compound 4: middle estimate off by 1.0-fold (0.01 log units), on the high side, and the stated range covers the measured number.
By their numbers in this assay, from the lowest: compounds 2, 3, 4 and 1 (each within the scatter of the next).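

In this assay, replacing isopropyl with vinyl on a saturated chain carbon bound to an oxygen on an aromatic ring gives a 1.0-fold lower number from compound 1 to compound 4 (0.01 log units; within the scatter), which lies within the scatter. Among these compounds, at this position, then, a shorter end carrying a double bond reads the same as a branched saturated end, which the earlier compounds, all without a double bond outside the aromatic rings, could not show. No measurement shown here accounts for this result. Still open, on these data alone, is whether an amine or a carboxylic acid on this chain would move the number beyond the scatter.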